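A few compounds are considered here, and "the series" means these few. Any claim that something is new, unique, unknown or untested is made for them only; others in the source may bear on it.

In a functional assay on HeLa cells (Homo sapiens) for inhibition, read by MTT assay, with a stated time of 48 h (on this read-out lower numbers stand for stronger inhibition and higher numbers for weaker inhibition), three compounds sharing one core have been measured. Compound 1 `CCOC(=O)C1=C(N/N=C(\c2ccc([N+](=O)[O-])cc2)N2CCN(c3ccc(F)cc3)CC2)Nc2[nH]nc(C)c2C1c1ccc(N(C)C)cc1` gives 87000 nM, compound 2 `CCOC(=O)C1=C(N/N=C(/Cl)c2ccc([N+](=O)[O-])cc2)Nc2[nH]nc(C)c2C1c1ccc(N(C)C)cc1` gives 46200 nM and compound 3 `CCOC(=O)C1=C(N/C=N/c2ccc(C)cc2)Nc2[nH]nc(C)c2C1c1ccc(N(C)C)cc1` gives 43200 nM. Compound 2 therefore sits within the usual scatter of both compound 1 and compound 3, and its number cannot be ranked against either of them.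

Compound 4 `CCOC(=O)C1=C(N/C=N/c2ccc([N+](=O)[O-])cc2)Nc2[nH]nc(C)c2C1c1ccc(N(C)C)cc1` has not yet been measured. Its structural change from compound 2 is a group of 11 heavy atoms (7 carbon, 2 nitrogen, 2 oxygen; one six-membered aromatic ring of carbon only) in place of a group of 12 heavy atoms (7 carbon, 2 nitrogen, 2 oxygen, 1 chlorine; one six-membered aromatic ring of carbon only), on an amine nitrogen. The group that leaves is the one holding the chlorine, and the core stays as it was.

For the measured compounds named here, one measured step bears directly on this change, since it also replaces that chlorine-bearing group on the amine nitrogen: a 1.1-fold lower number from compound 2 to compound 3 (0.03 log units; within the scatter). That step stays within the scatter, so it gives no reason to expect a real shift. Going by the values given here, compound 1 offers no measured step of this kind. Among the compounds with values here, the data hold only this single example, so the expectation remains modest.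

The expected step is a 1.1-fold lower number from compound 2 to compound 4 (0.04 log units; within the scatter), which is no change beyond the scatter. For compound 4 the estimated value is 42000 nM, with an expected range of 20000 nM to 90000 nM.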

Compound 4, half-maximal inhibitory concentration: 57800 nM
For compound 4 the middle estimate is 1.4-fold (0.14 log units) below the measured one, within the range that was stated.
By their numbers in this assay, from the lowest: compounds 3, 2, 4 and 1 (each within the scatter of the next).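

In this assay, the replacement of the chlorine-bearing group on the amine nitrogen now has a second example, a 1.3-fold higher number from compound 2 to compound 4 (0.10 log units; within the scatter), alongside a 1.1-fold lower number from compound 2 to compound 3 (0.03 log units; within the scatter), and both stay within the scatter. For the compounds shown here, the new compound also gives the first comparison on the aromatic ring of this side group: nitro in place of methyl on an aromatic carbon gives a 1.3-fold higher number from compound 3 to compound 4 (0.13 log units; within the scatter), which again is no change beyond the scatter, so neither the replacement on the amine nitrogen nor this exchange on the ring has yet shifted the read-out measurably. No measurement is available that would explain why these changes leave the number within the scatter.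

The compounds shown leave open whether an amine or a carboxylic acid on that aromatic carbon, in place of the nitro or the methyl, would move the number beyond the scatter. They also leave open whether changes elsewhere on the shared core, such as a longer chain in place of the ethyl of the ester, would have any larger effect in this assay.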